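Phenyl in place of bromo on the nitro-bearing ring

The source may hold more compounds than are shown below. What is called first, only, known or untested is meant among the compounds shown, and "the series" means these compounds.

Compound 1, `CN1CCC[C@H]1COc1cccc([N+](=O)[O-])c1`, gives 31.2 nM in an assay on membranes from Cerebral cortex for displacement of a labelled ligand from Neuronal acetylcholine receptor; alpha4/beta2 (Rattus norvegicus), with a stated time of 30 min; a lower number here means a stronger inhibitor, a higher number a weaker inhibitor.
Compound 2, `CN1CCC[C@H]1COc1cc(C#CCCCCO)cc([N+](=O)[O-])c1`, gives 14.2 nM in this assay.
Compound 3, `CN1CCC[C@H]1COc1cc(Br)cc([N+](=O)[O-])c1`, gives 55 nM in this assay.

Compound 3 has the highest of the three numbers. The step of a 1.8-fold higher number from compound 1 to compound 3 (0.25 log units; within the scatter) stays within the scatter, whereas a 3.9-fold higher number from compound 2 to compound 3 (0.59 log units; beyond the scatter) goes beyond it. Compound 4, `CN1CCC[C@H]1COc1cc(-c2ccccc2)cc([N+](=O)[O-])c1`, differs from compound 3 by phenyl in place of bromo on an aromatic carbon. Among the compounds with values here, the steps that bear on this change are a 2.2-fold lower number from compound 1 to compound 2 (0.34 log units; beyond the scatter) and a 3.9-fold higher number from compound 2 to compound 3 (0.59 log units; beyond the scatter): a larger group at this carbon went with a lower number, while bromo gave the highest number. A modest step downward in this assay is therefore expected. Compound 4 is estimated at 30 nM, between 10 nM and 90 nM. For compound 4 this estimate means a 1.8-fold lower number from compound 3 to compound 4 (0.26 log units; within the scatter).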

Compound 4, inhibition constant: 330 nM
Compound 4: the middle estimate sits 11-fold (1.04 log units) below what was measured; the whole stated range lies below it.
By their numbers in this assay, from the lowest: compound 2; then compounds 1 and 3 (each within the scatter of the next); then compound 4.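

At this aromatic carbon, the size of the group alone does not set the number in this assay: phenyl in place of bromo gives a 6.0-fold higher number from compound 3 to compound 4 (0.78 log units; beyond the scatter), although the larger 6-hydroxyhex-1-yn-1-yl had gone with a lower number. Phenyl also compares poorly with that chain, at a 23-fold higher number from compound 2 to compound 4 (1.37 log units; beyond the scatter), and with plain hydrogen, at an 11-fold higher number from compound 1 to compound 4 (1.02 log units; beyond the scatter), so it gives the highest number of the four compounds.

Nothing measured here gives a reason for this rise. On these data alone, whether a phenyl ring carrying an amine, or a shorter chain ending in a carboxylic acid, would follow phenyl or 6-hydroxyhex-1-yn-1-yl stays open.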